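A few compounds are considered here, and "the series" means these few. Any claim that something is new, unique, unknown or untested is made for them only; others in the source may bear on it.

Compound 3 `CCOC(=O)CCCCCOc1cccc(CN(C(=O)c2ccccc2)C(C)C)c1` is the ethyl ester of compound 1 `CC(C)N(Cc1cccc(OCCCCCC(=O)O)c1)C(=O)c1ccccc1`. In an ADME assay on BJ cells (Homo sapiens) for cytotoxicity, read by CellTiter-Glo and resazurin assay, with a stated time of 72 h (on this read-out higher numbers stand for an effect only at larger amounts of compound and lower numbers for an effect already at smaller amounts), compound 3 gives only a limit, > 26000 nM. Compound 1 also reaches only a limit in this assay, > 26000 nM. The step from the acid to its ester, a step that the two limits leave unreadable from compound 1 to compound 3, cannot be sized, because both ends sit on (the limit of > 26000 nM in this assay, at which 3 of the 3 values shown sit).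

Compound 4 `CCOC(=O)CCCCCOc1cccc(CN(C(=O)c2ccc(-c3ccc4ccccc4c3)cc2)C(C)C)c1` differs from compound 3 in one place: naphthalen-2-yl in place of hydrogen on an aromatic carbon. The closest measured parallel is compound 2 `CC(C)N(Cc1cccc(OCCCCCC(=O)O)c1)C(=O)c1ccc(-c2ccc3cc[nH]c3c2)cc1`, which carries 1H-indol-6-yl on the same aromatic carbon of compound 1. In this assay compound 2 likewise shows only a limit, > 26000 nM. Hence the step that the two limits leave unreadable from compound 1 to compound 2 is not readable either; all that is seen is that adding a ring system there did not bring cytotoxicity into the measured window.

On this footing, the expected step that the limit leaves unreadable from compound 3 to compound 4 is none that can be told from the scatter. Compound 4 is therefore estimated at 30000 nM in this assay, within 8000 nM to 110000 nM, and the measurement is most likely to return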

Compound 4, half-maximal effective concentration: > 26000 nM
Compound 4: only a limit was reported; the forecaster's own chance of this, stated with the estimate: 70%; the middle value does not contradict the limit.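

The step from compound 3 to compound 4 cannot be read, because both compounds end on the same limit: the limit of > 26000 nM in this assay, at which 4 of the 4 values shown sit.

The compounds shown leave open at what amount, if any, each becomes cytotoxic, and whether adding naphthalen-2-yl changes that amount at all.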